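A few compounds are considered here, and "the series" means these few. Any claim that something is new, unique, unknown or untested is made for them only; others in the source may bear on it.

Measured compounds in a functional assay on HeLa cells (Homo sapiens) for cytotoxicity, read by cell counting, with a stated time of 4 days; a higher number here means a weaker inhibitor, a lower number a stronger inhibitor:
- compound 1, `Nc1cccc(/C=C2\SC(=O)N(Cc3cccc(Cl)c3)C2=O)c1`, gives 250000 nM
- compound 2, `CC(C)(C)c1ccc(CN2C(=O)S/C(=C\c3ccc(N)cc3)C2=O)cc1`, gives 53000 nM
- compound 3, `CC(C)(C)c1ccc(CN2C(=O)S/C(=C\c3cccc(N)c3)C2=O)cc1`, gives 145000 nM

Compound 1 has the highest of the three numbers; compound 3 lies within the scatter of it, while compound 2 lies beyond. The difference between the core of compound 1 and the core of compound 3 is not broken down here. Between compound 3 and compound 2 the change is 4-aminophenyl in place of 3-aminophenyl on a double-bonded chain carbon bound to a double-bonded ring carbon, and it gave a 2.7-fold lower number from compound 3 to compound 2 (0.44 log units; beyond the scatter). Compound 4, `Nc1ccc(/C=C2\SC(=O)N(Cc3cccc(Cl)c3)C2=O)cc1`, is not yet measured; it differs from compound 1 by 4-aminophenyl in place of 3-aminophenyl on a double-bonded chain carbon bound to a double-bonded ring carbon, the same change, which occurs twice among these compounds. Because compound 3 to compound 2 gave a 2.7-fold lower number from compound 3 to compound 2 (0.44 log units; beyond the scatter), a step of similar size is expected, namely a 2.6-fold lower number from compound 1 to compound 4 (0.42 log units; beyond the scatter). Compound 4 is estimated at 95000 nM, between 40000 nM and 250000 nM.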

Compound 4, half-maximal inhibitory concentration: 24000 nM
Compound 4: the middle estimate sits 4.0-fold (0.60 log units) above what was measured, outside the stated range (below it).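

In this assay, 4-aminophenyl in place of 3-aminophenyl gave a 10-fold lower number from compound 1 to compound 4 (1.02 log units; beyond the scatter). The change lowered the number on both cores, but the size of the step did not carry over: the same change on two cores in this assay, a 2.7-fold lower number (0.44 log units; beyond the scatter) from compound 3 to compound 2 and a 10-fold lower number (1.02 log units; beyond the scatter) from compound 1 to compound 4, 3.8-fold (0.58 log units) apart, beyond the scatter of two such steps. These two pairs therefore support the direction of the change in this series but do not give a step size that can be transferred from one core to another, and they do not show which difference between the cores goes with the larger step.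

As far as these compounds go, whether a hydroxyl or a carboxylic acid in place of the amine would respond to the same move remains open. So does the size of the step on any third core.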